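Swapping the triazole substituent: from aryl to chlorobenzyl

A few compounds are considered here, and "the series" means these few. Any claim that something is new, unique, unknown or untested is made for them only; others in the source may bear on it.

Compound 1, with the structure `Cc1ccc(-n2cc(CSC(=S)N3CCN(C(=O)OC(C)(C)C)CC3)nn2)cc1`, carries a 4-methylphenyl group on the triazole ring of a shared core that also holds a dithiocarbamate linked to a piperazine. In a functional assay on PC-3 cells (Homo sapiens) for inhibition, read by MTT assay, with a stated time of 72 h (a higher number here means a weaker inhibitor, a lower number a stronger inhibitor), compound 1 gives > 128000 nM, which is a limit of the assay rather than a measured number. Compound 2, with the structure `O=C(OCc1ccccc1)N1CCN(C(=S)SCc2cn(Cc3ccc(Cl)cc3)nn2)CC1`, is a related analogue. In this assay compound 2 gives > 128000 nM, again a limit and not a number. Compound 1 therefore stands at the limit of > 128000 nM in this assay, at which 2 of the 2 values shown sit, so there is no measured number to compare it against.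

Compound 3, with the structure `CC(C)(C)OC(=O)N1CCN(C(=S)SCc2cn(Cc3ccccc3Cl)nn2)CC1`, has not yet been measured in this assay. It differs from compound 1 in one place: 2-chlorobenzyl in place of 4-methylphenyl on an aromatic nitrogen. Among the compounds with values here, no measured pair of compounds with a comparable change is available, so the size of this step cannot be read from the data. Both measured values sit at the same limit, and the expectation is that the step that the limit leaves unreadable from compound 1 to compound 3 stays within the scatter. Compound 3 is accordingly estimated at 150000 nM, with a range from 50000 nM to 500000 nM, most likely reported again as a limit.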

Compound 3, half-maximal inhibitory concentration: 12500 nM
Compound 3: middle estimate off by 12-fold (1.08 log units), on the high side; the measured number lies below the stated range.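

The position on the aromatic nitrogen turns out to matter for activity in this series, which the first two compounds could not show because neither gave a number. In this assay, putting 2-chlorobenzyl in place of 4-methylphenyl gives an at least 10-fold lower number from compound 1 to compound 3 (1.01 log units; beyond the scatter), and compound 3 reaches a real measured value of 12500 nM, so the shared core can register as active in these cells when this substituent changes. This step is a minimum and not an exact size, since one end of it is a limit of the assay, and the true gap could be larger: the limit of > 128000 nM in this assay, at which 2 of the 3 values shown sit.

The change alters two things at once, bringing in chlorine and replacing a ring attached directly to the nitrogen with a benzyl group, and the compounds shown cannot tell which of the two accounts for the step. An unsubstituted benzyl or a 2-chlorophenyl group at this position would separate the two, and a 4-methoxybenzyl group would begin to show how much the substituent on the benzyl ring matters.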